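The compounds below may be only part of what the source reports. "The series", "measured", "known", "first", "only" and "open" are said of these compounds alone.

Measured so far:
Compound 1, `O=C(/C=C/c1ccncc1)c1ccccc1`, gives 49000 nM in a functional assay with Rattus norvegicus as the target; on this read-out higher numbers stand for weaker inhibition and lower numbers for stronger inhibition.
Compound 2, `N#Cc1cccc(C(=O)/C=C/c2ccncc2)c1`, gives 85000 nM in this assay.

Compound 1 holds the lowest of these two numbers, and its nearest neighbour is compound 2; the change a 1.7-fold higher number from compound 1 to compound 2 (0.24 log units; within the scatter), which puts cyano in place of hydrogen on an aromatic carbon, stays within the scatter, so the two cannot be told apart.

Compound 3, `CSc1ccc(C(=O)/C=C/c2ccncc2)cc1`, has not yet been tested. It differs from compound 1 by methylsulfanyl in place of hydrogen on an aromatic carbon. Going by the values given here, the only measured step concerns a different group placed on the same ring of the shared core, and it produced no shift beyond the scatter. On that basis no clear movement in this assay is expected either way, and compound 3 is estimated to lie close to compound 1, with the step of a 1.1-fold lower number from compound 1 to compound 3 (0.04 log units; within the scatter) expected to remain small. Compound 3 is therefore expected at about 45000 nM, in a range from 12000 nM to 170000 nM.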

Compound 3, half-maximal inhibitory concentration: 33000 nM
Compound 3: middle estimate off by 1.4-fold (0.13 log units), on the high side; measured number inside the range.
By their numbers in this assay, from the lowest: compounds 3, 1 and 2 (each within the scatter of the next, the first and the last beyond it).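

In this assay, methylsulfanyl in place of hydrogen, on an aromatic carbon para to a large group, gives a 1.5-fold lower number from compound 1 to compound 3 (0.17 log units; within the scatter), so this change cannot be told apart from compound 1. Going by these compounds alone, until now the only change tested on this ring was cyano; with methylsulfanyl there are two different groups, and neither moves the number beyond the scatter. No other measurement bears on this result.

Going by these compounds, it remains open whether a group of another kind at this same place, such as an amine or a carboxylic acid, would shift the number clearly. A longer chain ending in sulfur, or methylsulfanyl at another carbon of the same ring, is equally untested in the compounds shown here.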